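The compounds below may be only part of what the source reports. "The series", "measured", "known", "first", "only" and "open" are said of these compounds alone.

Compound 2 `Cc1ccc(C(CCN(C)C)NC(=O)CCc2ccc(C(F)(F)F)cc2)cc1` stands lowest of the two compounds measured in a functional assay on NIH3T3 cells for agonist activity at Urotensin-2 receptor (Homo sapiens), with a stated time of 5 days (on this read-out lower numbers stand for smaller maximal responses and higher numbers for larger maximal responses), where compound 2 gives 60%. Compound 1 `Cc1ccc(C(CCN(C)C)NC(=O)CCc2ccccc2)cc1` gives 73% in this assay, and the step of a number 13 percentage points lower from compound 1 to compound 2 (beyond the scatter) lies beyond the scatter. Compound 3 `CN(C)CCC(NC(=O)CCc1ccc(C(F)(F)F)cc1)c1ccc(Cl)cc1` differs from compound 2 by chloro in place of methyl on an aromatic carbon. For the measured compounds named here, no measured step concerns this exchange: the only step known, a number 13 percentage points lower from compound 1 to compound 2 (beyond the scatter), concerns trifluoromethyl in place of hydrogen, so it bears on compound 3 only as a sign that a single substituent exchange on an aromatic carbon has moved this assay by a modest amount. Without a direct precedent, compound 3 is expected to stay near compound 2, with an expected step of no change at the digits printed from compound 2 to compound 3 (within the scatter) that lies within the scatter. The estimate for compound 3 in this assay is 60%, with an expected range from 45% to 75%.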

Compound 3, largest response reached (reported as efficacy), in percent of the reference or control that the assay uses: 73%
Compound 3: the middle estimate sits 13 percentage points below what was measured, within the range that was stated.
By their numbers in this assay, from the lowest: compound 2; then compounds 1 and 3 (each within the scatter of the next).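

In this assay the exchange of 4-methylphenyl for 4-chlorophenyl gives a number 13 percentage points higher from compound 2 to compound 3 (beyond the scatter), so this place, para to a large group, does affect the maximal response, even though one heavy atom replaces another and the counts of rings, hydrogen-bond donors, hydrogen-bond acceptors and net charge stay the same. The earlier step, a number 13 percentage points lower from compound 1 to compound 2 (beyond the scatter), lay at a different place and ran in the opposite direction, so substituent exchanges on aromatic carbons in this series can move the number either way. Nothing available accounts for this rise.

Going by these compounds, whether the rise is particular to chloro or would also appear with fluoro, bromo or methoxy at this place remains open. On these data alone, it is also open whether chloro would give a similar step in a compound carrying hydrogen in place of the trifluoromethyl group.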